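This account rests on a few compounds, and the source may have more. Where it says the series, first, only, none or still open, it means among the compounds named here.

The measured set in a functional assay on NCI-H226 cells (Homo sapiens) for inhibition, read by sulforhodamine B assay, with a stated time of 48 h, tested at 10 uM (on this read-out higher numbers stand for a weaker effect at the one concentration tested and lower numbers for a stronger effect), comprises three compounds:
Compound 1 `COc1cc(Cl)cc(-c2nn(-c3cccc(NC(=O)c4ccc(Cl)c(Cl)c4)c3)cc2-c2ccncc2)c1` gives 66.3% in this assay.
Compound 2 `O=C(Nc1cccc(-n2cc(-c3ccncc3)c(-c3cc(O)cc(Cl)c3)n2)c1)Nc1ccc(Cl)c(Cl)c1` gives 14.5% in this assay.
Compound 3 `COc1cc(Cl)cc(-c2nn(-c3cccc(NC(=O)Nc4cc(C(F)(F)F)cc(C(F)(F)F)c4)c3)cc2-c2ccncc2)c1` gives -5.97% in this assay.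

Compound 3 stands lowest of the three numbers. Its nearest neighbour is compound 2, whose number is higher by more than the scatter, and compound 1 lies furthest, higher again beyond the scatter. Compound 4 `COc1cc(Cl)cc(-c2nn(-c3cccc(NC(=O)Nc4cccc(C(F)(F)F)c4)c3)cc2-c2ccncc2)c1` differs from compound 3 in one place: hydrogen in place of trifluoromethyl on an aromatic carbon. Going by the values given here, no step between two measured compounds isolates this change, so its size has to be guessed. The step of a number 21 percentage points higher from compound 3 to compound 4 (beyond the scatter) is expected to be a moderate rise in the number, likely somewhat beyond the scatter, since compound 3 with -5.97% leaves room only for a weaker effect. Compound 4 is therefore estimated at 15%, within a range from -8% to 45%.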

Compound 4, a percentage reported as activity, at one concentration (the size of the read-out at that concentration, not a potency): 3.94%
For compound 4 the middle estimate is 11.1 percentage points above the measured one, and the stated range covers the measured number.
By their numbers in this assay, from the lowest: compounds 3 and 4 (each within the scatter of the next); then compound 2; then compound 1.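

Taking one trifluoromethyl off the aromatic carbon gives, in this assay, a number 9.9 percentage points higher from compound 3 to compound 4 (within the scatter) and so shows that the second trifluoromethyl is not needed to keep the effect at this position. By contrast, (3-(trifluoromethyl)phenyl)amino in place of 3,4-dichlorophenyl on the carbonyl carbon gives a number 62.4 percentage points lower from compound 1 to compound 4 (beyond the scatter) and marks that change as the far larger one. Nothing measured here gives a reason for either step.

Going by these compounds, whether an amine or a carboxylic acid at this aromatic carbon would hold the effect stays open. So does how compound 3 and compound 4 compare at other concentrations.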